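The source may hold more compounds than are shown below. What is called first, only, known or untested is meant among the compounds shown, and "the series" means these compounds.

Compound 3 `CC1(C)C[C@H](Nc2cc(NCc3cnccc3C(F)(F)F)ncc2C#N)CC[C@@H]1O` gives the lowest number in an assay on isolated protein for inhibition of protein kinase C theta type (Homo sapiens), read by TR-FRET, with a stated time of 2 h (on this read-out lower numbers stand for stronger inhibition and higher numbers for weaker inhibition), at 7 nM. Its nearest neighbour is compound 2 `CNC(=O)[C@H]1CC[C@@H](Nc2cc(NCc3cnccc3C(F)(F)F)ncc2C#N)CC1`, which in this assay gives 27 nM, and the furthest is compound 1 `CO[C@H]1CC[C@H](CNc2cc(NCc3cnccc3C(F)(F)F)ncc2C#N)CC1`, which gives 330 nM. The change to compound 4 `CC1(C)[C@@H](C(N)=O)C[C@H]1Nc1cc(NCc2cnccc2C(F)(F)F)ncc1C#N` is 3-carbamoyl-2,2-dimethylcyclobutyl in place of 4-hydroxy-3,3-dimethylcyclohexyl on a nitrogen on an aromatic ring. Among the compounds with values here, no measured step makes exactly this change. Within the data shown here, the nearest precedent is a 3.9-fold lower number from compound 2 to compound 3 (0.59 log units; beyond the scatter), where a hydroxy-bearing ring replaced a carbamoyl-bearing ring; compound 4 reverses that, moving back to a carbamoyl, now on a four-membered ring. The step of a 47-fold lower number from compound 1 to compound 3 (1.67 log units; beyond the scatter) shows that the group on this nitrogen can move the number strongly, but it compares against a differently linked group and so only sets the scale. On balance a modest rise in the number is expected, roughly undoing the gain seen from compound 2 to compound 3, so that compound 4 is estimated at a 2.9-fold higher number from compound 3 to compound 4 (0.46 log units; beyond the scatter). Compound 4 is therefore expected to give about 20 nM in this assay, within a range from 6 nM to 70 nM.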

Compound 4, half-maximal inhibitory concentration: 1.4 nM
Compound 4: the middle estimate sits 14-fold (1.15 log units) above what was measured, outside the stated range (below it).
By their numbers in this assay, from the lowest: compound 4; then compound 3; then compound 2; then compound 1.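

In this assay, the 3-carbamoyl-2,2-dimethylcyclobutyl group on this nitrogen goes beyond the 4-hydroxy-3,3-dimethylcyclohexyl group, with a 5.0-fold lower number from compound 3 to compound 4 (0.70 log units; beyond the scatter) as the step, so the order of compound 2 and compound 3 does not make a hydroxy-bearing ring the better choice over every carbamoyl-bearing ring. Within the data shown here, the wider comparisons, a 19-fold lower number from compound 2 to compound 4 (1.29 log units; beyond the scatter) and a 240-fold lower number from compound 1 to compound 4 (2.37 log units; beyond the scatter), show that this position spans more of the read-out than the earlier compounds revealed, and that a four-membered ring is accepted here. Nothing available accounts for the gain.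

Compound 4 differs from compound 2 in ring size, the methyl groups and the amide together, so their separate contributions stay unresolved. From the compounds shown here alone, it also remains open how a carboxylic acid or an amine would read in place of the carbamoyl on the four-membered ring.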